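The compounds below may be only part of what the source reports. "The series", "measured", "known", "first", "only" and "open" are said of these compounds alone.

Compound 1 `CC(=O)N1CCN(c2nc(NC(c3ccccc3)c3ccccc3)c3c(n2)C(=O)N(C(C)C)C3)CC1`: < 1000 nM
Compound 2 `CC(=O)N1CCN(c2nc(N[C@H](C)c3ccc(C)cc3)c3c(n2)C(=O)N(C(C)C)C3)CC1`: 260000 nM

Both compounds were tested in a physicochemical assay for solubility, measured as thermodynamic solubility, at pH 7.4; a lower number here means a less soluble compound, a higher number a more soluble compound. Compound 1 gives < 1000 nM, and that figure is a limit of the assay, not a number. Among the compounds with values here, compound 2, at 260000 nM, therefore holds the only true number in the set, and it stands far up the scale from compound 1.

Compound 3 `CCOc1ccc([C@@H](C)Nc2nc(N3CCN(C(C)=O)CC3)nc3c2CN(C(C)C)C3=O)cc1` differs from compound 2 in one place: ethoxy in place of methyl on an aromatic carbon. This is ethoxy in place of methyl on an aromatic carbon, para to a large group, so that 4-methylphenyl becomes 4-ethoxyphenyl. Within the data shown here, no pair of measured compounds shows a change of this kind, so the expectation rests on the structural difference alone and is held loosely. Starting from compound 2 at 260000 nM, a modest fall is expected. There is little expected chance of reaching a limit of the assay. The estimated change is a 2.4-fold lower number from compound 2 to compound 3 (0.37 log units; beyond the scatter). For compound 3 the estimated value is 110000 nM, with an expected range from 30000 nM to 300000 nM.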

Compound 3, solubility: 120000 nM
Estimate against measurement, compound 3: 1.1-fold (0.04 log units) below, within the range that was stated.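

In this assay, within the data shown here, replacing methyl with ethoxy on an aromatic carbon para to a large group gives a 2.2-fold lower number from compound 2 to compound 3 (0.34 log units; beyond the scatter), the first step in the set that can be read between two true numbers. The position therefore responds to this change, although the step is modest, and compound 3 still gives a true number, 120000 nM, rather than a limit. The only limit in the set belongs to compound 1, which differs from compound 3 in more than one place and so offers no step to set beside this one: the limit of < 1000 nM in this assay, at which 1 of the 3 values shown sits.

From the compounds shown here alone, whether the step goes with the oxygen or with the length of the chain stays open, and a methoxy or a propyl group at this position would separate the two. Also open, going by these compounds, is how an amine or a carboxylic acid on this aromatic carbon would read in this assay, and whether the same change would give a similar step with a different group on the nitrogen of the shared core.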